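The source may report more compounds than this note shows. Statements on the series, on what has been measured and on what is new or still open speak of the compounds shown alone.

The three measured compounds share one core and were all tested in a functional assay on A549 cells (Homo sapiens) for inhibition, with a stated time of 72 h; a lower number here means a stronger inhibitor, a higher number a weaker inhibitor. Compound 1 `COc1ccc(NC(=O)Nc2nc(Sc3c[nH]c4ccccc34)cc(N3CCN(c4ccccn4)CC3)n2)cc1` reaches only the limit of the assay, > 50000 nM. Compound 2 `O=C(Nc1ccccc1)Nc1nc(NC2CC2)cc(Sc2c[nH]c3ccccc23)n1` likewise gives only a limit, > 50000 nM. Compound 3 `O=C(Nc1ccc(Cl)cc1)Nc1nc(Sc2c[nH]c3ccccc23)cc(N2CCCCC2)n1` gives a number, 18600 nM. Among the measured compounds shown here, compound 2 therefore stands at the limit at which two of the three values sit (the limit of > 50000 nM in this assay, at which 2 of the 3 values shown sit), and no measured step leads away from it. Compound 4 `O=C(Nc1ccccc1)Nc1nc(Nc2ccc(Cl)cc2)cc(Sc2c[nH]c3ccccc23)n1` differs from compound 2 by 4-chlorophenyl in place of cyclopropyl on a nitrogen on an aromatic ring, so that cyclopropylamino becomes (4-chlorophenyl)amino. No step between measured compounds is shown, so the size of this change has no precedent among the numbers given. This assay is expected to report for compound 4 a weak value again, moving little beyond the usual scatter, with a fair chance that only a limit is reported once more. The estimate for compound 4 is 30000 nM, with a range from 8000 nM to 100000 nM. This corresponds to an expected step from compound 2 to compound 4 of an at least 1.6-fold lower number from compound 2 to compound 4 (0.22 log units; that floor lies within the scatter).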

Compound 4, half-maximal inhibitory concentration: 48400 nM
Compound 4: the middle estimate sits 1.6-fold (0.21 log units) below what was measured; low and high end bracket the measured number.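

In this assay compound 4 gives a number, 48400 nM. Compound 2 gives only a limit. The change from cyclopropylamino to (4-chlorophenyl)amino is read as an at least 1.0-fold lower number from compound 2 to compound 4 (0.01 log units; that floor lies within the scatter). This step is only a floor because one end of it is not a number: the limit of > 50000 nM in this assay, at which 2 of the 4 values shown sit. Among the compounds shown here, what compound 4 adds is a first reading for an aromatic ring of carbon only on this nitrogen, and that ring does not take the compound clear of the limit by more than the scatter.

As far as these compounds go, how far compound 2 truly lies from compound 4 remains unknown, and the chlorine of the 4-chlorophenyl group cannot be judged on its own. From the compounds shown here alone, it also stays open how this assay would respond to a longer alkyl chain or a carboxylic acid on this nitrogen.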